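Halogen swap on the pendant phenyl: notes on the series

The source may report more compounds than this note shows. Statements on the series, on what has been measured and on what is new or still open speak of the compounds shown alone.

Measured so far:
compound 1, `O=C(NOCc1ccccc1F)c1cn(-c2ccccc2)nc1-c1ccccc1`, 75700 nM
compound 2, `O=C(NOCc1ccccc1Cl)c1cn(-c2ccccc2)nc1-c1ccccc1`, 82100 nM
compound 3, `O=C(NOCc1ccccc1)c1cn(-c2ccccc2)nc1-c1ccc(Cl)cc1`, 51900 nM

All three were run in an ADME assay on HEK-293T cells (Homo sapiens) for antiproliferative activity, read by MTT assay, with a stated time of 48 h, in the presence of a further agent that is not named here; a higher number here means that more compound is tolerated, a lower number that less compound is tolerated. Compound 2 and compound 1 differ by fluoro in place of chloro on an aromatic carbon, and the step is a 1.1-fold lower number from compound 2 to compound 1 (0.04 log units; within the scatter). Compound 3 carries its substituent on the other phenyl; the difference between the core of compound 3 and the core of compound 2 is not broken down here. Compound 3 gives the lowest of the three numbers, but it lies within the scatter of both compound 1 and compound 2, so no order among the three can be read.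

Compound 4, `O=C(NOCc1ccccc1)c1cn(-c2ccccc2)nc1-c1ccc(F)cc1`, is not yet measured. It differs from compound 3 by fluoro in place of chloro on an aromatic carbon. This is the same kind of change as that from compound 2 to compound 1, but the place differs: there the fluoro sits ortho to a large group, here para to a large group.

In this assay the step from compound 3 to compound 4 is expected to be a 1.1-fold lower number from compound 3 to compound 4 (0.03 log units; within the scatter), because the corresponding step of a 1.1-fold lower number from compound 2 to compound 1 (0.04 log units; within the scatter) stayed within the scatter. Compound 4 is estimated at 48000 nM, with a likely range from 25000 nM to 95000 nM.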

Compound 4, half-maximal cytotoxic concentration: 217000 nM
Compound 4: the middle estimate sits 4.5-fold (0.66 log units) below what was measured; the whole stated range lies below it.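

In this assay, fluoro in place of chloro on the 4-chlorophenyl group gives a 4.2-fold higher number from compound 3 to compound 4 (0.62 log units; beyond the scatter). The change therefore does not carry over with a fixed size between these two cores: the same change on two cores in this assay, a 1.1-fold lower number (0.04 log units; within the scatter) from compound 2 to compound 1 and a 4.2-fold higher number (0.62 log units; beyond the scatter) from compound 3 to compound 4, 4.5-fold (0.66 log units) apart, beyond the scatter of two such steps. This does not show that the core alone sets the size of the step, since the two pairs also differ in the place of the halogen, and two pairs give no rule for any further core in the series.

Still open, as far as these compounds go, is whether fluoro or chloro accounts for the gap between the two values, and a compound with plain phenyl, 4-bromophenyl or 4-methoxyphenyl on the same core would help to settle this. Also open, from the compounds shown here alone, is whether the halogen's place or the rest of the core decides the size of the step, which a pair carrying chloro and fluoro at the same place on the core of compound 1 could separate.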